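The compounds below may be only part of what the source reports. "The series", "measured", "known", "first", "only" and "open" are said of these compounds alone.

Measured compounds:
- compound 1, `CCC(CC)S(=O)(=O)c1ccc(S(=O)(=O)N2CCC[C@@H](C(=O)N3CCC(F)(F)CC3)C2)cc1`: 13 nM
- compound 2, `O=C([C@@H]1CCCN(S(=O)(=O)c2ccc(S(=O)(=O)C3COC3)cc2)C1)N1CCC(F)(F)CC1`: 110 nM
- compound 3, `CC(C)S(=O)(=O)c1ccc(S(=O)(=O)N2CCC[C@@H](C(=O)N3CCC(F)(F)CC3)C2)cc1`: 11 nM

These three share a core and differ only in the group on the sulfonyl sulfur. In a functional assay on MIA PaCa-2 cells (Homo sapiens) for inhibition, read by MTT assay, with a stated time of 7 days (a lower number here means a stronger inhibitor, a higher number a weaker inhibitor), compound 3 gives the lowest number of the three, but its separation from compound 1 is a 1.2-fold lower number from compound 1 to compound 3 (0.07 log units; within the scatter), within the scatter, so the two cannot be ordered. Compound 2 lies well apart: a 10-fold lower number from compound 2 to compound 3 (1.00 log units; beyond the scatter).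

Compound 4, `CN(C)S(=O)(=O)c1ccc(S(=O)(=O)N2CCC[C@@H](C(=O)N3CCC(F)(F)CC3)C2)cc1`, is not yet measured. Its change from compound 3 is dimethylamino in place of isopropyl on a sulfonyl sulfur. For the measured compounds named here, no measured step swaps an alkyl for a nitrogen-linked group at this position. The steps that come closest are a 1.2-fold lower number from compound 1 to compound 3 (0.07 log units; within the scatter), where one alkyl replaced another with no change beyond the scatter, and an 8.5-fold higher number from compound 1 to compound 2 (0.93 log units; beyond the scatter) together with a 10-fold lower number from compound 2 to compound 3 (1.00 log units; beyond the scatter), where a ring bearing an oxygen took the place of an alkyl and the number rose modestly. Dimethylamino is neither an alkyl nor a ring, so the nearest guide is only that small groups without a ring at this sulfur have stayed close to compound 3.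

Compound 4 is therefore expected to give about 25 nM in this assay, within 8 nM to 80 nM, a step of a 2.3-fold higher number from compound 3 to compound 4 (0.36 log units; beyond the scatter) that is estimated to stay near the scatter.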

Compound 4, half-maximal inhibitory concentration: 118 nM
The estimate for compound 4 lay 4.7-fold (0.67 log units) below the measured number; measured number above the stated range.
By their numbers in this assay, from the lowest: compounds 3 and 1 (each within the scatter of the next); then compounds 2 and 4 (each within the scatter of the next).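

In this assay, dimethylamino in place of isopropyl on a sulfonyl sulfur gives a large step (an 11-fold higher number from compound 3 to compound 4 (1.03 log units; beyond the scatter)), and the same group in place of pentan-3-yl gives a modest one (a 9.1-fold higher number from compound 1 to compound 4 (0.96 log units; beyond the scatter)). At this position, then, a group with no ring and the same count of heavy atoms as isopropyl did not stay close to compound 3, and the ring of oxetan-3-yl is not needed for a number in the range of compound 2, as compound 2 and compound 4 cannot be ordered (a 1.1-fold higher number from compound 2 to compound 4 (0.03 log units; within the scatter)). Nothing measured here accounts for the shift, so what lies behind it stays unassigned.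

With dimethylamino the only nitrogen-linked group shown, the compounds leave open whether other amines on this sulfur, such as pyrrolidine, morpholine or an unsubstituted amine, would give numbers like that of compound 4. They also leave open whether a methyl or ethyl group would stay with isopropyl and pentan-3-yl, or whether a cyclopropyl ring would fall nearer to oxetan-3-yl.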